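Para-methyl on the anilide of a thiourea series

A few compounds are considered here, and "the series" means these few. Any claim that something is new, unique, unknown or untested is made for them only; others in the source may bear on it.

Compound 1 `CCOC(=O)C1=C(C)NC(=S)NC1c1cn(-c2ccccc2)nc1-c1ccc(Cl)cc1` and compound 2 `CC1=C(C(=O)Nc2ccccc2)C(c2cn(-c3ccccc3)nc2-c2ccc(Cl)cc2)NC(=S)N1` share a core and differ only at the carbonyl carbon, where an anilino group replaces ethoxy. In a functional assay on MCF7 cells (Homo sapiens) for inhibition, read by sulforhodamine B assay, with a stated time of 24 h (on this read-out lower numbers stand for stronger inhibition of growth and higher numbers for weaker inhibition of growth), compound 1 gives 33200 nM, and compound 2 gives 61500 nM; the step of a 1.9-fold higher number from compound 1 to compound 2 (0.27 log units; within the scatter) is within the scatter, so the two numbers are not told apart. Compound 2 thus sits at the upper of two values without standing clear of compound 1.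

Compound 3 `CC1=C(C(=O)Nc2ccc(C)cc2)C(c2cn(-c3ccccc3)nc2-c2ccc(Cl)cc2)NC(=S)N1` takes the change (methyl in place of hydrogen on an aromatic carbon), that is, methyl in place of hydrogen on an aromatic carbon of the anilide ring, para to a large group. For the measured compounds named here, no measured step touches this position: the only step known concerns the carbonyl substituent, not the anilide ring. With nothing to lean on, the expected step of a 1.0-fold lower number from compound 2 to compound 3 (0.01 log units; within the scatter) is none beyond the scatter, and compound 3 is estimated at 60000 nM, ranging from 25000 nM to 150000 nM.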

Compound 3, concentration for 50% growth inhibition: 43500 nM
For compound 3 the middle estimate is 1.4-fold (0.14 log units) above the measured one; measured number inside the range.
By their numbers in this assay, from the lowest: compounds 1, 3 and 2 (each within the scatter of the next).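

In this assay, methyl in place of hydrogen on an aromatic carbon of the anilide ring, para to a large group, gives a 1.4-fold lower number from compound 2 to compound 3 (0.15 log units; within the scatter) and so does not separate compound 3 from compound 2. For the compounds shown here, the whole replacement of ethoxy by (4-methylphenyl)amino on the carbonyl carbon gives a 1.3-fold higher number from compound 1 to compound 3 (0.12 log units; within the scatter) and does not separate those two compounds either, so the methyl adds the first reading at this ring position without a change that can be told from the scatter. Nothing measured here explains these numbers.

The compounds shown leave open whether a different group at this ring position, such as a methoxy group, a chlorine atom or a carboxylic acid, would move the number beyond the scatter. They also leave open how a longer chain in place of the methyl would read.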